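Returning an aryl group to the saturated ring carbon

The source may report more compounds than this note shows. Statements on the series, on what has been measured and on what is new or still open speak of the compounds shown alone.

Three compounds share one core and differ only in the group on a saturated ring carbon. Compound 1 `Cc1cc(O)c(C2=NN(c3ccc(S(N)(=O)=O)cc3)C(c3ccccc3O)C2)cc1Cl` gives 6850 nM in a functional assay on TK-10 cells (Homo sapiens) for antiproliferative activity, with a stated time of 48 h; on this read-out higher numbers stand for weaker inhibition of growth and lower numbers for stronger inhibition of growth. Compound 2 `Cc1cc(O)c(C2=NN(c3ccc(S(N)(=O)=O)cc3)C(c3ccccc3Cl)C2)cc1Cl` gives 5860 nM in this assay, and the step of a 1.2-fold lower number from compound 1 to compound 2 (0.07 log units; within the scatter) is a change of chloro in place of hydroxy that does not rise above the scatter. Compound 3 `Cc1cc(O)c(C2=NN(c3ccc(S(N)(=O)=O)cc3)C(/C=C/c3ccccc3)C2)cc1Cl` gives 29900 nM and so stands with the highest of the three numbers; the steps of a 4.4-fold higher number from compound 1 to compound 3 (0.64 log units; beyond the scatter) and a 5.1-fold higher number from compound 2 to compound 3 (0.71 log units; beyond the scatter) both mark the 2-phenylethenyl group as weaker than either of the two substituted phenyl groups.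

Compound 4 `COc1ccc(C2CC(c3cc(Cl)c(C)cc3O)=NN2c2ccc(S(N)(=O)=O)cc2)cc1OC` is not yet measured. The change from compound 3 is 3,4-dimethoxyphenyl in place of 2-phenylethenyl on a saturated ring carbon. The two steps that bear on it run in the opposite sense, from an aryl group to the 2-phenylethenyl group, and both were modest and beyond the scatter. Since compound 4 carries an aryl group again, the expected step of a 4.0-fold lower number from compound 3 to compound 4 (0.60 log units; beyond the scatter) is a modest fall, back toward the region of compound 1 and compound 2. Compound 4 is therefore estimated at 7500 nM in this assay, within a range from 3000 nM to 20000 nM.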

Compound 4, concentration for total growth inhibition: 18400 nM
Compound 4: middle estimate off by 2.5-fold (0.39 log units), on the low side; the range from low to high includes it.
By their numbers in this assay, from the lowest: compounds 2 and 1 (each within the scatter of the next); then compounds 4 and 3 (each within the scatter of the next).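

Carrying an aryl group on this saturated ring carbon is not enough on its own to return the number to the level of compound 1 and compound 2: a 1.6-fold lower number from compound 3 to compound 4 (0.21 log units; within the scatter) stays within the scatter, so in this assay 3,4-dimethoxyphenyl and 2-phenylethenyl cannot be told apart. The steps of a 3.1-fold higher number from compound 2 to compound 4 (0.50 log units; beyond the scatter) and a 2.7-fold higher number from compound 1 to compound 4 (0.43 log units; beyond the scatter) are both modest but beyond the scatter, which shows that the groups on the phenyl ring matter here, with 2-chlorophenyl and 2-hydroxyphenyl both giving lower numbers than 3,4-dimethoxyphenyl. Nothing available explains this difference between the aryl groups.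

Going by these compounds, it remains open whether the higher number of compound 4 goes with the two methoxy groups together or with only one of them, and an unsubstituted phenyl or a 4-methoxyphenyl group on this carbon would help to separate these cases. On these data alone, it is also open how a phenyl ring bearing an amine or a carboxylic acid at this position would compare with compound 1 and compound 2 in this assay.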